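The source may report more compounds than this note shows. Statements on the series, on what has been measured and on what is new or still open speak of the compounds shown alone.

Measured so far:
- compound 1 `Oc1ccc(-c2cc(-c3cccs3)cc(-c3cccc(O)c3)n2)cc1`: 1.1%
- compound 2 `Oc1ccc(-c2cc(-c3cccnc3)cc(-c3ccccc3O)n2)cc1`: 0%

In an assay on isolated protein for inhibition of DNA topoisomerase 1 (Homo sapiens), with a stated time of 30 min, tested at 20 uM (on this read-out higher numbers stand for a stronger effect at the one concentration tested and lower numbers for a weaker effect), compound 1 gives 1.1% and compound 2 gives 0%. Compound 2 holds the lowest of the two numbers, but its nearest neighbour, compound 1, lies within the scatter, so the pair reads as one level: essentially no inhibition.

Compound 3 `Oc1ccc(-c2cc(-c3cccnc3)cc(-c3cccc(O)c3)n2)cc1` is not yet measured. It differs from compound 2 in one place: 3-hydroxyphenyl in place of 2-hydroxyphenyl on an aromatic carbon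

Among the measured compounds shown here, no step between measured compounds is available to size this change. Both measured compounds sit at the floor of this assay, so no step beyond the scatter is expected for compound 3; the step of a number 2 percentage points higher from compound 2 to compound 3 (within the scatter) is an estimate of no real movement. Compound 3 is expected to give about 2%, within 0% to 12%.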

Compound 3, a percentage reported as inhibition, at one concentration (the size of the read-out at that concentration, not a potency): 2.8%
Compound 3: middle estimate off by 0.8 percentage points, on the low side; the measured number falls inside the stated range.
By their numbers in this assay, from the lowest: compounds 2, 1 and 3 (each within the scatter of the next).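

In this assay 3-hydroxyphenyl in place of 2-hydroxyphenyl next to the ring nitrogen gives a number 2.8 percentage points higher from compound 2 to compound 3 (within the scatter) and so does not separate these two hydroxyphenyl groups at this position. With 3-hydroxyphenyl held in place, pyridin-3-yl in place of thiophen-2-yl gives a number 1.7 percentage points higher from compound 1 to compound 3 (within the scatter) and so does not separate these two rings either; all three compounds stay at the floor of the assay. Nothing on hand bears on why this level holds. Still open, as far as these compounds go, is whether a group of another kind at either position, such as an aminomethyl or a carboxylic acid, would lift the read-out off this floor.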